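The source may hold more compounds than are shown below. What is called first, only, known or untested is meant among the compounds shown, and "the series" means these compounds.

Measured compounds in a functional assay on the whole organism (blood, strain Wistar-Okamoto) with Rattus norvegicus as the target, with a stated time of 5 days; on this read-out lower numbers stand for an effect already at smaller amounts and higher numbers for an effect only at larger amounts of compound:
Compound 1 `N#CN/C(=N\CC1CCCO1)Nc1cccnc1`: compound 1 gives 50 mg/kg
Compound 2 `CC(C)(C)C/N=C(\NC#N)Nc1ccncc1`: compound 2 gives 5 mg/kg
Compound 3 `N#CN/C(=N\Cc1ccccc1)Nc1ccncc1`: compound 3 gives 5 mg/kg

Compound 2 stands level with compound 3 on this assay, and together these two carry the lowest of the three numbers; compound 1 is the furthest away, with a higher number beyond the scatter. Going by the values given here, the only measured step that touches a single change is no change at the digits printed from compound 2 to compound 3 (within the scatter), which shows that swapping the group on the saturated chain carbon left the minimum effective dose where it was.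

Compound 4 `N#CN/C(=N\c1ccccc1)Nc1ccncc1` differs from compound 2 by phenyl in place of neopentyl on a double-bonded nitrogen. Among the compounds with values here, no measured pair places the phenyl directly on the double-bonded nitrogen, so the step from compound 2 to compound 3 bears on it only loosely: it shows the phenyl itself is tolerated when a chain carbon sits between, but says nothing of its removal. The expectation is therefore a step of about a 2.0-fold higher number from compound 2 to compound 4 (0.30 log units; within the scatter), leaning toward a somewhat higher number, and compound 4 is estimated at 10 mg/kg, within a range from 3 mg/kg to 30 mg/kg.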

Compound 4, minimum effective dose: 50 mg/kg
The estimate for compound 4 lay 5.0-fold (0.70 log units) below the measured number; measured number outside the range, above it.
By their numbers in this assay, from the lowest: compounds 2 and 3 (each within the scatter of the next); then compounds 1 and 4 (each within the scatter of the next).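

In this assay, placing phenyl directly on the double-bonded nitrogen in place of neopentyl gives a 10-fold higher number from compound 2 to compound 4 (1.00 log units; beyond the scatter) and so shows that this position does not accept every change equally. The earlier step, no change at the digits printed from compound 2 to compound 3 (within the scatter), had shown only that a phenyl carried on a saturated chain carbon left the number in place, so the same ring is tolerated in one setting and linked to a clear rise in the other. No measurement shown here accounts for the rise.

Going by these compounds, it remains open whether the rise goes with the aromatic ring itself or with the loss of the saturated chain carbon. A cyclohexyl group on the double-bonded nitrogen, or a phenyl bearing a methoxy group, would bear on that question.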